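Swapping a furan for a tolyl group on a dioxide core

This account rests on a few compounds, and the source may have more. Where it says the series, first, only, none or still open, it means among the compounds named here.

Of the compounds shown here, three have been measured in a physicochemical assay for lipophilicity, read by HPLC, measured as octanol-water partition; a lower number here means a more polar compound, a higher number a more lipophilic compound. Compound 1 `N#Cc1c(-c2ccco2)[n+]([O-])c2ccc(C3OCCO3)cc2[n+]1[O-]` gives 2. Compound 2 `O=C(N/N=C/c1ccc2no[n+]([O-])c2c1)c1cccc(O)c1` gives 1.2, and compound 3 `Nc1ccc(C(=O)N/N=C/c2ccc3no[n+]([O-])c3c2)cc1` gives 1.2. Compound 1 stands highest of the three, and its gap to compound 2 and to compound 3 lies beyond the scatter. Among the measured compounds shown here, the one measured step, no change at the digits printed from compound 2 to compound 3 (within the scatter), exchanges one aryl group for another on a carbonyl carbon and does not touch the core of compound 1.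

Compound 4 `Cc1ccc(-c2c(C#N)[n+]([O-])c3cc(C4OCCO4)ccc3[n+]2[O-])cc1` differs from compound 1 by 4-methylphenyl in place of furan-2-yl on an aromatic carbon. For the measured compounds named here, no measured step covers this kind of exchange, so the expectation rests on what is counted: a hydrogen-bond acceptor leaves and two more carbon atoms enter. A rise in this assay is therefore expected, rather than no change. The expected step is a number 1.00 log units higher from compound 1 to compound 4 (beyond the scatter). Compound 4 is estimated at 3, within a range from 2.4 to 3.6.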

Compound 4, partition coefficient: 1.6
For compound 4 the middle estimate is 1.40 log units above the measured one; the whole stated range lies above it.
By their numbers in this assay, from the lowest: compounds 2 and 3 (each within the scatter of the next); then compound 4; then compound 1.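

In this assay, putting 4-methylphenyl in place of furan-2-yl on this aromatic carbon, next to the ring nitrogen and ortho to the cyano group, gives a number 0.40 log units lower from compound 1 to compound 4 (beyond the scatter). Among the compounds shown here, this is the first measured step at this position, and it shows that counting atoms does not settle the direction here: the entering group has more carbon atoms and no hydrogen-bond acceptor, yet the number goes down. Nothing available here explains this result.

On these data alone, whether other groups at this position, such as an unsubstituted phenyl, a thiophene or an amine, would follow the same direction remains open. One step also cannot show whether this exchange would shift the number the same way with a carboxylic acid in place of the cyano group.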